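A few compounds are considered here, and "the series" means these few. Any claim that something is new, unique, unknown or untested is made for them only; others in the source may bear on it.

Measured compounds:
- Compound 1, `COc1ccc(-c2cc3ccccc3c(-c3cccc(N)c3)n2)cc1`: in an assay on isolated protein for inhibition of DNA topoisomerase 1 (Homo sapiens), with a stated time of 30 min, tested at 100 uM (a higher number here means a stronger effect of the compound at the concentration tested, a lower number a weaker effect), compound 1 gives 0%.
- Compound 2, `COc1ccc(-c2cc3ccccc3c(-c3ccc(O)cc3)n2)cc1`: in this assay compound 2 gives 6.7%.
- Compound 3, `COc1cc(OC)cc(-c2cc3ccccc3c(-c3cccc(N)c3)n2)c1`: in this assay compound 3 gives 0%.

Compound 1 and compound 2 differ by 4-hydroxyphenyl in place of 3-aminophenyl on an aromatic carbon, and the step is a number 6.7 percentage points higher from compound 1 to compound 2 (within the scatter). Compound 4, `COc1cc(OC)cc(-c2cc3ccccc3c(-c3ccc(O)cc3)n2)c1`, is not yet measured; it arises from compound 3 by the same kind of change, (4-hydroxyphenyl in place of 3-aminophenyl on an aromatic carbon), the surroundings differing only in that the place in compound 1 is described as meta to a 4-methoxyphenyl group (8 heavy atoms) while in compound 3 it is meta to a large group. How the core of compound 1 and the core of compound 3 differ is not broken down here; their values are level. Since compound 3 gives 0% and the earlier step was a number 6.7 percentage points higher from compound 1 to compound 2 (within the scatter), the step is expected to be a number 5 percentage points higher from compound 3 to compound 4 (within the scatter). Compound 4 is estimated at 5%, between 0% and 15%.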

Compound 4, a percentage reported as inhibition, at one concentration (the size of the read-out at that concentration, not a potency): 0%
For compound 4 the middle estimate is 5 percentage points above the measured one; low and high end bracket the measured number.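

In this assay, 4-hydroxyphenyl in place of 3-aminophenyl gives no change at the digits printed from compound 3 to compound 4 (within the scatter), and the two cores do not separate on this change: the same change on two cores in this assay, a number 6.7 percentage points higher (within the scatter) from compound 1 to compound 2 and no change at the digits printed (within the scatter) from compound 3 to compound 4, 6.7 percentage points apart, within the scatter of two such steps. The result shows that, on these two cores, the change had no effect that could be told from the scatter, so the steps agree. It does not show that the change carries a real effect from one core to the other, as neither step is beyond the scatter, and agreement between two such small steps says little about how the change would behave on a further core.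

The compounds shown leave open whether a carboxylic acid or an amide on this phenyl ring would give a read-out clear of the scatter. They also leave open whether a longer chain there would do so on either core.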